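A few compounds are considered here, and "the series" means these few. Any claim that something is new, unique, unknown or untested is made for them only; others in the source may bear on it.

Measured compounds:

Compound 1 `O=C1Nc2ccccc2/C1=N/NC(=S)Nc1ccccc1`, > 25000 nM
Compound 2 `COc1cccc(NC(=O)N/N=C2\C(=O)Nc3ccccc32)c1`, > 25000 nM
Compound 3 `CN1C(=O)/C(=N\NC(=S)Nc2ccccc2)c2ccccc21`, > 25000 nM

In an ADME assay on RD cells (Homo sapiens) for cytotoxicity (a lower number here means that less compound is tolerated, a higher number that more compound is tolerated), compound 1 gives > 25000 nM, which is a limit of the assay and not a number. Compound 2 gives > 25000 nM, also a limit. Compound 3 gives > 25000 nM, again a limit. Compound 3 therefore stands at the assay limit, and the two further values shown sit at that same limit. Among the compounds with values here, the step that the two limits leave unreadable from compound 1 to compound 3 is the only measured step, and the two limits leave its size unreadable.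

Compound 4 `CCN1C(=O)/C(=N\NC(=S)Nc2ccccc2)c2ccccc21` differs from compound 3 by methyl in place of hydrogen on a saturated chain carbon bound to an amide-type nitrogen in a ring. Within the data shown here, the one measured step that bears on it, a step that the two limits leave unreadable from compound 1 to compound 3, gives no readable size, and because the limit of > 25000 nM in this assay, at which 3 of the 3 values shown sit, holds for all three values there is no sign of any compound reaching a measurable number in this assay. No step beyond the scatter is therefore expected, and compound 4 is expected most likely to return another limit. The estimate for compound 4 is 40000 nM, in the range 15000 nM to 150000 nM, which is expected to mean a step that the limit leaves unreadable from compound 3 to compound 4.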

Compound 4, half-maximal cytotoxic concentration: > 25000 nM
Compound 4 was reported as a limit (the forecaster's own chance of this, stated with the estimate: 75%); the middle value does not contradict the limit.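

Compound 4, like compound 1 and compound 3, sits at a limit of the assay rather than at a number, so neither of its steps from those two compounds can be read. The compounds shown leave open at what concentration any of them becomes toxic in this assay.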